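Fluoro for trifluoromethyl: compound 3 to compound 4

A few compounds are considered here, and "the series" means these few. Any claim that something is new, unique, unknown or untested is made for them only; others in the source may bear on it.

Measured so far:
compound 1, `Cn1c(CN2CCN(c3ccc(C(F)(F)F)cc3)CC2)nc2ccccc21`, 84%
compound 2, `Cn1c(CN2CCN(c3ncc(C(F)(F)F)cc3Cl)CC2)nc2ccccc21`, 71%
compound 3, `Cn1c(CN2CCN(c3ccccc3C(F)(F)F)CC2)nc2ccccc21`, 84%

In an assay on CHO cells with metabotropic glutamate receptor 2 (Homo sapiens) as the target, read by FLIPR (on this read-out higher numbers stand for larger maximal responses and lower numbers for smaller maximal responses), compound 3 gives 84%, level with compound 1 at 84% within the scatter, the two together the highest of the three; compound 2 at 71% sits lower, beyond the scatter.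

Compound 4, `Cn1c(CN2CCN(c3ccccc3F)CC2)nc2ccccc21`, differs from compound 3 by fluoro in place of trifluoromethyl on an aromatic carbon. For the measured compounds named here, no pair of measured compounds isolates this change, so nothing measured fixes its size. The expectation is a small step from compound 3 to compound 4, if anything slightly downward, and not beyond the scatter: the expected step is a number 5 percentage points lower from compound 3 to compound 4 (within the scatter). Compound 4 is estimated at 79% in this assay, with a range from 64% to 92%.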

Compound 4, largest response reached (Emax), in percent of the reference or control that the assay uses: 64%
For compound 4 the middle estimate is 15 percentage points above the measured one; the range from low to high includes it.
By their numbers in this assay, from the lowest: compounds 4 and 2 (each within the scatter of the next); then compounds 1 and 3 (each within the scatter of the next).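

In this assay, fluoro in place of trifluoromethyl on this aromatic carbon, ortho to a large group, gives a number 20 percentage points lower from compound 3 to compound 4 (beyond the scatter). For the compounds shown here, this is the first single-change step, and it shows that the maximal response is sensitive to the group at this place. No available evidence bears on the cause of this step.

On these data alone, whether chloro, methyl or methoxy at the same place would keep the response of trifluoromethyl remains open. Also open, as far as these compounds go, is whether the same replacement in compound 1 would give a step of similar size.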